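Pyridinyl in place of bromophenyl on a thiazolidinone core

This account rests on a few compounds, and the source may have more. Where it says the series, first, only, none or still open, it means among the compounds named here.

Measured compounds:
compound 1 `Cc1ccc(/C=C2\S/C(=N\c3csc(-c4ccc(Cl)cc4)c3)NC2=O)cc1` 1000 nM
compound 2 `O=C1N/C(=N/c2csc(-c3ccc(Cl)cc3)c2)S/C1=C\c1ccc(Br)cc1` 3300 nM

In a functional assay on HCT-116 cells (Homo sapiens) for cytotoxicity, read by MTT assay, with a stated time of 72 h (on this read-out higher numbers stand for weaker inhibition and lower numbers for stronger inhibition), compound 2 gives 3300 nM, the higher of the two numbers recorded; compound 1 sits below it, the step of a 3.3-fold higher number from compound 1 to compound 2 (0.52 log units; beyond the scatter). Compound 3 `O=C1N/C(=N/c2csc(-c3ccc(Cl)cc3)c2)S/C1=C\c1ccccn1` differs from compound 2 by pyridin-2-yl in place of 4-bromophenyl on a double-bonded chain carbon bound to a double-bonded ring carbon. For the measured compounds named here, no measured step bears directly on this change: the only step recorded concerns a group on that ring, not the ring itself. With no guide beyond that modest shift, compound 3 is expected to show no step beyond the scatter, a 1.3-fold lower number from compound 2 to compound 3 (0.12 log units; within the scatter). Compound 3 is therefore estimated at 2500 nM, in a range from 700 nM to 9000 nM.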

Compound 3, half-maximal inhibitory concentration: 21600 nM
Estimate against measurement, compound 3: 8.6-fold (0.94 log units) below; measured number above the stated range.
By their numbers in this assay, from the lowest: compound 1; then compound 2; then compound 3.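

Until now only the group on the aromatic ring had changed at this position. Exchanging the ring itself, in this assay, gives a 6.5-fold higher number from compound 2 to compound 3 (0.82 log units; beyond the scatter), and set against the 4-methylphenyl group it gives a 22-fold higher number from compound 1 to compound 3 (1.33 log units; beyond the scatter), so pyridin-2-yl carries the highest number of the three compounds. Nothing measured here accounts for this shift. On these data alone, it remains open whether the rise follows from the ring nitrogen or from the loss of the bromo or methyl group, and how a phenyl ring bearing an amine or a carboxylic acid would read at this position.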